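What the thioether arm is worth: compound 2 to compound 4

The compounds below may be only part of what the source reports. "The series", "measured", "known", "first", "only" and "open" are said of these compounds alone.

Measured in a functional assay on PC-9 cells (Homo sapiens) for inhibition, read by MTT assay, with a stated time of 72 h; on this read-out higher numbers stand for weaker inhibition and lower numbers for stronger inhibition:
Compound 1 `CCCCCc1c(C)nc2nc(SCc3ccc(Cl)cc3)nn2c1Nc1cc(-c2ccccc2)[nH]n1`: > 50000 nM
Compound 2 `Cc1cc(Nc2cc(-c3ccccc3)[nH]n2)n2nc(SCC(=O)c3ccccc3)nc2n1`: 4450 nM
Compound 3 `Cc1cc(Nc2ccn(Cc3ccc(F)cc3)n2)n2nc(SCc3ccc(Br)cc3)nc2n1`: 19400 nM

The value of compound 1 is a limit of the assay, not a number (the limit of > 50000 nM in this assay, at which 1 of the 3 values shown sits). Of the two numbers, compound 2 has the lower one; compound 3 gives a higher number, and that gap lies beyond the usual scatter.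

Compound 4 `Cc1cc(Nc2cc(-c3ccccc3)[nH]n2)n2ncnc2n1` is not yet measured. It differs from compound 2 in one place: hydrogen in place of (benzoylmethyl)sulfanyl on an aromatic carbon. For the measured compounds named here, no measured pair shows this change, so the step is a guess. The sulfur-linked groups of compounds 1, 2 and 3 all differ and their values spread widely, so removing this arm is expected to cost activity: compound 4 is expected at 15000 nM, between 3000 nM and 60000 nM, a step of a 3.4-fold higher number from compound 2 to compound 4 (0.53 log units; beyond the scatter) toward weaker inhibition.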

Compound 4, half-maximal inhibitory concentration: > 50000 nM
Compound 4: a limit, no number; the forecaster's own chance of this, stated with the estimate: 30%; at least 3.3-fold (0.52 log units) between middle value and limit.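

For the compounds shown here, the first single-change pair at this position shows that the arm matters: on the aromatic carbon between two ring nitrogen atoms, hydrogen in place of (benzoylmethyl)sulfanyl gives an at least 11-fold higher number from compound 2 to compound 4 (1.05 log units; beyond the scatter) on this read-out. The value of compound 4 is a limit of the assay, not a number: the limit of > 50000 nM in this assay, at which 2 of the 4 values shown sit.

Which part of the arm counts, the sulfur, the carbonyl or the phenyl ring, stays open. So does whether a smaller group at this carbon, such as an amine or a methylsulfanyl, would keep any of the activity.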